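The source may report more compounds than this note shows. Statements on the series, on what has been measured and on what is new or still open speak of the compounds shown alone.

Working notes on the series. Compound 1 `CCOC(=O)c1cnc(N2CCN(Cc3cccc(F)c3)CC2)nc1Oc1c(C)cc(-c2ccc(C#N)cc2)cc1C` is the reference point for this step. In an ADME assay on MT4 cells (Homo sapiens) for cytotoxicity, read by MTT assay, with a stated time of 4 days (a lower number here means that less compound is tolerated, a higher number that more compound is tolerated), compound 1 gives > 125000 nM, which is a limit of the assay and not a number. Among the measured compounds shown here, compound 2 `CCOC(=O)c1cnc(N2CCN(Cc3ccc(C(N)=O)cc3)CC2)nc1Oc1c(C)cc(-c2ccc(C#N)cc2)cc1C` is the only member of this small set with a numerical value: in this assay compound 2 gives 66500 nM. Compound 3 `CCOC(=O)c1cnc(N2CCN(Cc3ccc(S(C)(=O)=O)cc3)CC2)nc1Oc1c(C)cc(-c2ccc(C#N)cc2)cc1C` again reaches a limit: in this assay compound 3 gives > 125000 nM. The steps among these three are small or unreadable: an at least 1.8-fold lower number from compound 1 to compound 2 (0.27 log units; that floor lies within the scatter), a step that the two limits leave unreadable from compound 1 to compound 3 and an at least 1.8-fold higher number from compound 2 to compound 3 (0.27 log units; that floor lies within the scatter). Two of the three values sit at the limit of > 125000 nM in this assay, at which 2 of the 3 values shown sit.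

Compound 4 `CCOC(=O)c1cnc(N2CCN(Cc3cccc(OC)c3)CC2)nc1Oc1c(C)cc(-c2ccc(C#N)cc2)cc1C` has not yet been measured. It differs from compound 1 as follows: methoxy in place of fluoro on an aromatic carbon. For the measured compounds named here, all the measured steps alter the aryl group on the saturated chain carbon bound to an amine nitrogen in a ring, and none of them shows a step beyond the scatter in this assay. Going by the values given here, the carbamoyl and methylsulfonyl variants are the only available comparisons, and both leave the picture near the limit set by compound 1. The expected step is therefore a number no higher from compound 1 to compound 4 (the limit leaves the size open), nothing beyond the scatter. For compound 4 the estimated value in this assay is 125000 nM, with a range from 60000 nM to 250000 nM, and most likely reported again only as a limit.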

Compound 4, half-maximal cytotoxic concentration: > 125000 nM
Compound 4: only a limit was reported (the forecaster's own chance of this, stated with the estimate: 65%); the middle value sits exactly at the limit.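

Compound 1 and compound 4 differ only by methoxy in place of fluoro, meta to a large group, so this change leaves the substituent on the same ring carbon and tests the group itself. In this assay compound 4 gives > 125000 nM, which is a limit of the assay and not a number. Among the compounds shown here, the steps to compound 4 from compound 1 and from compound 3 join two limits and cannot be read, the one readable step is an at least 1.8-fold higher number from compound 2 to compound 4 (0.27 log units; that floor lies within the scatter), and this change therefore adds nothing beyond the scatter, with the values gathering at a single limit: the limit of > 125000 nM in this assay, at which 3 of the 4 values shown sit.

The compounds shown leave open whether an amine, a carboxylic acid or a longer alkoxy chain on this ring would give a numerical value in this assay rather than another limit. Also open, going by these compounds, is how far the true values of compound 1, compound 3 and compound 4 lie from one another, as a limit gives no size.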